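The source may report more compounds than this note shows. Statements on the series, on what has been measured and on what is new or still open speak of the compounds shown alone.

Compound 3 `COc1cc2ncnc(Nc3ccc(F)c(Cl)c3)c2cc1NC(=O)N/N=C/c1cccc(Br)c1` carries the same core as compound 1 `O=C(N/N=C/c1cccc(Br)c1)Nc1cc2c(Nc3ccc(F)c(Cl)c3)ncnc2cc1O[C@H]1CCOC1` and compound 2 `CC(C)(C)c1cc(/C=N/NC(=O)Nc2cc3c(Nc4ccc(F)c(Cl)c4)ncnc3cc2O[C@H]2CCOC2)cc(C(C)(C)C)c1O`, an anilinoquinazoline-type scaffold bearing a semicarbazone arm. In a functional assay on A549 cells (Homo sapiens) for cytotoxicity, read by MTT assay, with a stated time of 72 h (on this read-out lower numbers stand for stronger inhibition and higher numbers for weaker inhibition), compound 3 gives 28100 nM, the highest of the three numbers and thus the weakest inhibition seen so far. Its closest neighbour is compound 2, which in this assay gives 19000 nM, a gap that lies within the usual scatter. Among the compounds with values here, the only single-point step measured runs a 2.6-fold higher number from compound 1 to compound 3 (0.42 log units; beyond the scatter), so compound 1, which in this assay gives 10700 nM, sits clearly below compound 3.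

Compound 4 `COc1cc2ncnc(Nc3ccc(F)c(Cl)c3)c2cc1NC(=O)N/N=C/c1ccc(O)cc1O` differs from compound 3 at the arm rather than at the core: 2,4-dihydroxyphenyl in place of 3-bromophenyl on a carbon with a double bond to nitrogen. Within the data shown here, no measured step touches this position, so the one step on record, concerning the oxygen substituent, gives no guide. What the numbers do show is that compound 1 and compound 2, which carry different groups on that same carbon, land not far apart, which suggests that this position moves the number only modestly. The step from compound 3 to compound 4 is therefore expected to stay within the scatter, with no clear direction, as a 1.1-fold lower number from compound 3 to compound 4 (0.05 log units; within the scatter). Compound 4 is estimated at 25000 nM, within a range from 9000 nM to 70000 nM.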

Compound 4, half-maximal inhibitory concentration: 31400 nM
Compound 4: middle estimate off by 1.3-fold (0.10 log units), on the low side; the range from low to high includes it.
By their numbers in this assay, from the lowest: compounds 1, 2, 3 and 4 (each within the scatter of the next, the first and the last beyond it).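

In this assay, within the data shown here, putting 2,4-dihydroxyphenyl in place of 3-bromophenyl on a carbon with a double bond to nitrogen gives a 1.1-fold higher number from compound 3 to compound 4 (0.05 log units; within the scatter), the first direct reading of a change at this position with everything else held the same. The exchange is a substantial one on paper, since the bromine goes and a group with hydrogen-bond donors and acceptors replaces one that has neither, yet this pair shows no measurable difference in the cell read-out. No measured information is available to explain why these two groups give such similar numbers.

As far as these compounds go, both groups compared here are six-membered aromatic rings of carbon only, so it remains open whether a phenyl ring carrying an amine or a carboxylic acid, a pyridine ring, or a plain alkyl chain on that carbon would also leave the number unchanged. From the compounds shown here alone, it is also open whether the same exchange would read the same way on a compound with oxolan-3-yl rather than methyl on the oxygen, as in compound 1.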